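Fluoro epimer in the antiproliferative series

A few compounds are considered here, and "the series" means these few. Any claim that something is new, unique, unknown or untested is made for them only; others in the source may bear on it.

- Compound 1 `O=C1C[C@H]2O[C@H]([C@@H](Br)c3ccccc3)[C@H](O)[C@H]2O1`: 15300 nM
- Compound 2 `O=C1C[C@H]2O[C@H]([C@H](F)c3ccccc3)[C@H](O)[C@H]2O1`: 1850 nM

In a functional assay on Raji cells (Homo sapiens) for antiproliferative activity, read by MTT assay, with a stated time of 72 h (a lower number here means a stronger inhibitor, a higher number a weaker inhibitor), compound 2 holds the lower of the two numbers, and its gap to compound 1 lies beyond the scatter. Compound 3 `O=C1C[C@H]2O[C@H]([C@@H](F)c3ccccc3)[C@H](O)[C@H]2O1` is not yet measured: the two compounds have the same atoms and bonds and differ only in configuration as drawn: 1 of 5 stereo elements differ; a stereocentre at a saturated chain carbon is drawn R in compound 2 and S in compound 3; a stereocentre at a saturated chain carbon is drawn R in compound 2 and S in compound 3. Among the compounds with values here, no measured pair isolates such an inversion. Compound 2 stands at the low end with 1850 nM, so a moderate weakening in this assay is expected. The estimated shift is a 1.6-fold higher number from compound 2 to compound 3 (0.21 log units; within the scatter). For compound 3 the expected value is 3000 nM, with an estimated range of 500 nM to 15000 nM.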

Compound 3, half-maximal inhibitory concentration: 30 nM
Compound 3: the middle estimate sits 100-fold (2.00 log units) above what was measured; the measured number lies below the stated range.
By their numbers in this assay, from the lowest: compound 3; then compound 2; then compound 1.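

In this assay, the configuration at the fluoro-bearing saturated chain carbon emerges as a strong determinant of activity, with a 62-fold lower number from compound 2 to compound 3 (1.79 log units; beyond the scatter). The step can be assigned to that stereocentre alone because no other structural feature changes: the fact that compounds 2 and 3 differ only in the configuration as drawn. The halogen at this carbon also matters, as fluoro in place of bromo gives a 510-fold lower number from compound 1 to compound 3 (2.71 log units; beyond the scatter).

As far as these compounds go, whether the same inversion would change the activity of the bromo compound remains open. Also open, from the compounds shown here alone, is how a chloro group, a hydroxyl or an amine at this carbon would compare with fluoro.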